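Pyrimidine attachment shift on the shared oxazole-ketone core

The source may hold more compounds than are shown below. What is called first, only, known or untested is meant among the compounds shown, and "the series" means these compounds.

In an assay (Rattus norvegicus) for inhibition of Fatty-acid amide hydrolase 1 (Homo sapiens) (on this read-out higher numbers stand for weaker inhibition and lower numbers for stronger inhibition), compound 2 `O=C(CCCCCCc1ccccc1)c1ncc(-c2ccncn2)o1` gives 2.3 nM, the lowest of the two numbers in hand. Going by the values given here, the only other measured member, compound 1 `Nc1ccccc1-c1cnc(C(=O)CCCCCCc2ccccc2)o1`, gives 750 nM in this assay; the step of a 330-fold lower number from compound 1 to compound 2 (2.51 log units; beyond the scatter) is large and well beyond the scatter, and it exchanges the whole group on that aromatic carbon of the shared core. Compound 3 `O=C(CCCCCCc1ccccc1)c1ncc(-c2cncnc2)o1` awaits measurement. It differs from compound 2 by pyrimidin-5-yl in place of pyrimidin-4-yl on an aromatic carbon; the two structures have the same atoms, joined differently, so the group and its counts are retained and only its point of attachment moves. Among the compounds with values here, no measured step in this assay addresses such a shift within the pyrimidine; the one step in hand, from compound 1 to compound 2, concerns a different substitution and indicates only that this position is sensitive to what sits on it. With that in mind a moderate weakening is expected, a 13-fold higher number from compound 2 to compound 3 (1.12 log units; beyond the scatter), well short of the step seen from compound 1 to compound 2. For compound 3 the estimate in this assay is 30 nM, within a range of 8 nM to 120 nM.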

Compound 3, inhibition constant: 22 nM
Compound 3: middle estimate off by 1.4-fold (0.13 log units), on the high side; low and high end bracket the measured number.
By their numbers in this assay, from the lowest: compound 2; then compound 3; then compound 1.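

In this assay, moving only the point of attachment gives a 9.6-fold higher number from compound 2 to compound 3 (0.98 log units; beyond the scatter), with the group and its counts unchanged. The position on the aromatic carbon next to the ring oxygen therefore responds to how the pyrimidine is joined, not only to which group sits there, which the exchange of whole groups between compound 1 and compound 2 could not show. The pyrimidin-5-yl group still gives a 34-fold lower number from compound 1 to compound 3 (1.53 log units; beyond the scatter), so both attachments lie on the low-number side of the 2-aminophenyl compound, and the shift within the pyrimidine is a modest step where each exchange of 2-aminophenyl for a pyrimidine is a large one; nothing available explains the difference between the two pyrimidine attachments.

The compounds shown leave open which of the two ring nitrogens, if either, accounts for the difference, a question that a pyridin-3-yl or pyridin-4-yl group, with a single ring nitrogen, or a plain phenyl group at the same carbon would bear on. They also leave open whether the gap between the pyrimidin-4-yl and pyrimidin-5-yl compounds persists when the chain ending in phenyl is shortened or lengthened.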